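The compounds below may be only part of what the source reports. "The series", "measured", "known", "first", "only" and "open" are said of these compounds alone.

Measured so far:
Compound 1, `CS(=O)(=O)c1ccc(N2CCc3c(OC4CCN(C(=O)OCCF)CC4)ncnc32)c(F)c1` — 86%
Compound 2, `CC(C)S(=O)(=O)N1CCC(Oc2ncnc3c2CCN3c2ccc(S(C)(=O)=O)cc2F)CC1` — 62%

In a functional assay on CHO-K1 cells with Glucose-dependent insulinotropic receptor (Homo sapiens) as the target, read by a luciferase reporter, with a stated time of 5 h (on this read-out lower numbers stand for smaller maximal responses and higher numbers for larger maximal responses), compound 2 gives 62%, the lowest of the two numbers; its nearest neighbour is compound 1, which gives 86%. Among the compounds with values here, the only step that has been measured is a number 24 percentage points lower from compound 1 to compound 2 (beyond the scatter), where isopropylsulfonyl replaced (2-fluoroethoxy)carbonyl on the ring amine nitrogen.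

Compound 3, `CS(=O)(=O)c1ccc(N2CCc3c(OC4CCN(C5=NCCCN5)CC4)ncnc32)c(F)c1`, has not yet been measured. It differs from compound 2 by a group of 6 heavy atoms (4 carbon, 2 nitrogen; one six-membered non-aromatic ring with 2 hetero atoms) in place of a group of 6 heavy atoms (3 carbon, 2 oxygen, 1 sulfur; no ring), on an amine nitrogen in a ring. Within the data shown here, no measured step exchanges the isopropylsulfonyl group for this six-membered ring, so the single step from compound 1 to compound 2 bears on the new change only loosely: it shows that a different group on this amine nitrogen moved the largest response by a modest amount. Compound 3 is therefore expected to lie between the two measured values, with a step of a number 12 percentage points higher from compound 2 to compound 3 (beyond the scatter). The estimate for compound 3 is 74%, with a range from 52% to 94%.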

Compound 3, largest response reached (reported as percent of maximum), in percent of the reference or control that the assay uses: 66%
Compound 3: middle estimate off by 8 percentage points, on the high side; the measured number falls inside the stated range.
By their numbers in this assay, from the lowest: compounds 2 and 3 (each within the scatter of the next); then compound 1.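

In this assay, putting a six-membered non-aromatic ring with 2 hetero atoms on the ring amine nitrogen in place of isopropylsulfonyl gives a number 4 percentage points higher from compound 2 to compound 3 (within the scatter). At this position, then, two groups that differ in ring content and in hydrogen-bond donor count cannot be told apart on largest response. The same ring in place of (2-fluoroethoxy)carbonyl gives a number 20 percentage points lower from compound 1 to compound 3 (beyond the scatter), so among these three compounds only compound 1 stands apart, and no information at hand accounts for this difference.

The compounds shown leave open whether the higher number of compound 1 depends on the carbonyl or on the fluorine of its chain, which an ethoxycarbonyl group on the same nitrogen could separate. As far as these compounds go, they also give only the largest response, so any change in potency across this series remains unknown.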